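Swapping a benzothiophene for a benzoyl on the thioether arm

A few compounds are considered here, and "the series" means these few. Any claim that something is new, unique, unknown or untested is made for them only; others in the source may bear on it.

The study measures growth inhibition of a breast cancer cell line with a functional assay on MCF7 cells (Homo sapiens) for inhibition, read by MTT assay, with a stated time of 72 h; a higher number here means a weaker inhibitor, a lower number a stronger inhibitor. Of the compounds shown here, two have numbers so far. Compound 1 `Cc1cc(Nc2cc(-c3ccccc3)[nH]n2)n2nc(SCc3csc4ccccc34)nc2n1` gives 3470 nM in this assay, the higher of the two numbers; compound 2 `Cc1cc(Nc2ccn(Cc3ccc(C(F)(F)F)cc3)n2)n2nc(SCc3ccc(Br)cc3)nc2n1` gives 2280 nM in this assay, and the gap between these two values lies within the scatter, so neither can be called the stronger inhibitor. The two compounds differ in more than one place, so nothing is learned about any single change from them.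

Compound 3 `Cc1cc(Nc2cc(-c3ccccc3)[nH]n2)n2nc(SCC(=O)c3ccccc3)nc2n1` is still to be measured. It shares the core of compound 1 and differs from it in one place: benzoyl in place of 1-benzothiophen-3-yl on a saturated chain carbon bound to a sulfur. Among the measured compounds shown here, no step between measured compounds isolates a change of this kind, so the expectation for compound 3 rests on the size and character of the groups alone, with one aromatic unit counted leaving and one entering. The step from compound 1 to compound 3 is expected to be small, a 1.0-fold higher number from compound 1 to compound 3 (0.00 log units; within the scatter), with no clear direction beyond the scatter. Compound 3 is therefore estimated at 3500 nM in this assay, within a range from 1400 nM to 9000 nM.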

Compound 3, half-maximal inhibitory concentration: 5240 nM
The estimate for compound 3 lay 1.5-fold (0.18 log units) below the measured number; the range from low to high includes it.
By their numbers in this assay, from the lowest: compounds 2, 1 and 3 (each within the scatter of the next, the first and the last beyond it).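

Among the compounds shown here, compound 3 supplies the first step that isolates a single change on the thioether arm: in this assay, benzoyl in place of 1-benzothiophen-3-yl on a saturated chain carbon bound to a sulfur gives a 1.5-fold higher number from compound 1 to compound 3 (0.18 log units; within the scatter). This read-out therefore does not separate the two arms, although one carries a five-membered and a six-membered aromatic ring while the other carries one six-membered aromatic ring and a double bond outside aromatic rings. No measurement shown here bears on why the two arms read alike.

The compounds shown leave open whether the number stays within the scatter when the group on this chain carbon has no aromatic ring, such as a short alkyl chain, a carboxylic acid or an amine. They also leave open whether the same exchange of benzoyl for 1-benzothiophen-3-yl would read alike with the remainder of compound 2, which differs from compound 1 in more than one place.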